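The source may report more compounds than this note shows. Statements on the series, on what has been measured and on what is new or still open speak of the compounds shown alone.

For the measured compounds named here, in an assay on isolated protein for antagonist activity at Bile acid receptor (Homo sapiens), read by HTRF, with a stated time of 30 min (a lower number here means a stronger inhibitor, a higher number a weaker inhibitor), compound 2 `CCC(=O)c1cc(CC)c(OCCCCCC(C)(C)c2nnn[nH]2)cc1O` gives 8500 nM, the higher of the two numbers so far; compound 1 `CCc1cc(C(C)=O)c(OC(C)c2ccccc2)cc1OCCCCCC(C)(C)c1nnn[nH]1` gives 1700 nM, and the gap between these two lies beyond the scatter. Compound 3 `CCc1cc(C(=O)c2ccccc2)c(O)cc1OCCCCCC(C)(C)c1nnn[nH]1` is the next entry: relative to compound 2, (phenyl in place of ethyl on a carbonyl carbon). Going by the values given here, no measured pair shows this change, so its effect is open. Compound 3 is expected to give a somewhat lower number, a step of a 2.1-fold lower number from compound 2 to compound 3 (0.33 log units; beyond the scatter) that may still fall within the scatter. The estimate for compound 3 is 4000 nM, in the range 1000 nM to 15000 nM.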

Compound 3, half-maximal inhibitory concentration: 3100 nM
Estimate against measurement, compound 3: 1.3-fold (0.11 log units) above, within the range that was stated.
By their numbers in this assay, from the lowest: compounds 1 and 3 (each within the scatter of the next); then compound 2.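

For the compounds shown here, on the carbonyl carbon, phenyl in place of ethyl gives a 2.7-fold lower number from compound 2 to compound 3 (0.44 log units; beyond the scatter) in this assay, the first change that can be read in one place. This position therefore accepts benzoyl as well as propanoyl, and the modest step favours benzoyl. No available evidence accounts for the step.

Open, as far as these compounds go, is how a cyclohexyl ring, a pyridyl ring or an amine on this carbonyl carbon would compare. Also open, from the compounds shown here alone, is whether a fluorine or methoxy group on the new phenyl would shift the number further.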